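Replacing a substituted phenyl on the shared core

The compounds below may be only part of what the source reports. "The series", "measured", "known", "first", "only" and "open" are said of these compounds alone.

The series shares one core, carried here by compound 1 `Cc1cc(=O)n(-c2ccccc2C(F)(F)F)nc1C(=O)Nc1ccc(Oc2ncnc3ccsc23)cc1` and compound 2 `Cc1cc(=O)n(-c2ccccc2OC(F)(F)F)nc1C(=O)Nc1ccc(Oc2ncnc3ccsc23)cc1`. In a functional assay on MCF7 cells (Homo sapiens) for cytotoxicity, read by MTT assay, with a stated time of 72 h (a lower number here means a stronger inhibitor, a higher number a weaker inhibitor), compound 1 gives 5550 nM, while compound 2 gives 23800 nM, which is the higher of the two measured numbers; the step of a 4.3-fold higher number from compound 1 to compound 2 (0.63 log units; beyond the scatter) shows that exchanging one group on that phenyl ring is enough to shift the read-out beyond the scatter. Compound 3 `Cc1ccc(-n2nc(C(=O)Nc3ccc(Oc4ncnc5ccsc45)cc3)c(C)cc2=O)cc1` has not yet been measured. It differs from compound 2 in one place: 4-methylphenyl in place of 2-(trifluoromethoxy)phenyl on an aromatic nitrogen. Among the measured compounds shown here, no measured step mirrors this exact change, since only the step from compound 1 to compound 2 touches that phenyl ring, and it kept the group in the same position. That step was modest, so a shift of similar size is expected here, with the direction open; because compound 1 gives 5550 nM without the trifluoromethoxy group, a somewhat lower number than compound 2 is estimated for compound 3 as a 3.0-fold lower number from compound 2 to compound 3 (0.47 log units; beyond the scatter). In this assay compound 3 is therefore expected to give about 8000 nM, within a range from 2500 nM to 25000 nM.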

Compound 3, half-maximal inhibitory concentration: 23800 nM
Compound 3: middle estimate off by 3.0-fold (0.47 log units), on the low side, within the range that was stated.
By their numbers in this assay, from the lowest: compound 1; then compounds 2 and 3 (each within the scatter of the next).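

The swap from 2-(trifluoromethoxy)phenyl to 4-methylphenyl on the aromatic nitrogen leaves no change at the digits printed from compound 2 to compound 3 (within the scatter) in this assay even though the group entering differs from the one leaving in both substituent and name position, whereas the earlier step changed only the substituent and kept its position. Among the compounds shown here, measured against 2-(trifluoromethyl)phenyl, the same 4-methylphenyl gives a 4.3-fold higher number from compound 1 to compound 3 (0.63 log units; beyond the scatter) and so matches the earlier step in size, which leaves compound 1 as the one compound of the three that stands apart, with compounds 2 and 3 level within the scatter. Nothing available bears on why these three aryl groups fall as they do.

The three compounds leave open whether the number of compound 1 belongs to the trifluoromethyl group itself or to its position on the ring, and how an unsubstituted phenyl would compare with all three. They also leave open whether an amine, a carboxylic acid or a longer alkyl chain on this phenyl ring would move the read-out away from compounds 2 and 3, and in which direction.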